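Dibromophenol pyrazoline amides: second acyl variant in PC-3 cytotoxicity

The source may hold more compounds than are shown below. What is called first, only, known or untested is meant among the compounds shown, and "the series" means these compounds.

Measured so far:
- compound 1 `CC1=NN(C(=O)COc2ccc(Cl)cc2)C(c2cc(Br)ccc2O)C1`: 49000 nM
- compound 2 `CC1=NN(C(=O)CCc2ccccc2)C(c2cc(Br)cc(Br)c2O)C1`: 11300 nM

In a functional assay on PC-3 cells (Homo sapiens) for cytotoxicity, read by MTT assay, with a stated time of 48 h (a lower number here means a stronger inhibitor, a higher number a weaker inhibitor), compound 2 gives 11300 nM and stands at the lowest of the two numbers; compound 1, the nearest, gives 49000 nM in this assay, a gap beyond the usual scatter. For the measured compounds named here, compound 1 and compound 2 differ in two places, so their values are only set side by side here; no single step is drawn between them.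

Compound 3 `CC1=NN(C(=O)COc2ccc(Cl)cc2)C(c2cc(Br)cc(Br)c2O)C1` is the next member. Against compound 2 the change is 4-chlorophenoxy in place of benzyl on a saturated chain carbon bound to a carbonyl carbon. Going by the values given here, no measured step covers this change on this core. The expectation for compound 3 in this assay is a move toward a higher number, that is a weaker inhibitor than compound 2, of about a 2.7-fold higher number from compound 2 to compound 3 (0.42 log units; beyond the scatter), beyond the scatter. Compound 3 is therefore estimated at 30000 nM in this assay, with a range from 10000 nM to 90000 nM.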

Compound 3, half-maximal inhibitory concentration: 40200 nM
For compound 3 the middle estimate is 1.3-fold (0.13 log units) below the measured one; low and high end bracket the measured number.
By their numbers in this assay, from the lowest: compound 2; then compounds 3 and 1 (each within the scatter of the next).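

On the core of compound 2, 4-chlorophenoxy in place of benzyl on a saturated chain carbon bound to a carbonyl carbon gives a 3.6-fold higher number from compound 2 to compound 3 (0.55 log units; beyond the scatter) in this assay and so reads as a loss of inhibition at this position. With 4-chlorophenoxy held fixed, bromo in place of hydrogen on an aromatic carbon gives a 1.2-fold lower number from compound 1 to compound 3 (0.09 log units; within the scatter) in this assay and so does not separate the two compounds. Nothing at hand explains either step.

The compounds shown leave open whether the bromo step would read the same with benzyl on the chain. Also open, from the compounds shown here alone, is how an amine, a carboxylic acid or a longer chain in place of benzyl would read in this assay on this core.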